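Swapping bromo for methyl in an amine oxidase B series

This account rests on a few compounds, and the source may have more. Where it says the series, first, only, none or still open, it means among the compounds named here.

Compound 1 `C#CCNC1CCc2c(SCCc3cccc(Br)c3)cccc21`: 620 nM
Compound 2 `C#CCNC1CCc2c(NCc3cccc(C(F)(F)F)c3)cccc21`: 11300 nM

In an ADME assay on isolated protein for inhibition of Amine oxidase [flavin-containing] B (Homo sapiens) (on this read-out higher numbers stand for weaker inhibition and lower numbers for stronger inhibition), compound 1 gives 620 nM. This is the lowest of the two numbers, so compound 1 is the stronger inhibitor of the pair. Compound 2 gives 11300 nM, a gap that lies well beyond the usual scatter of repeated measurements.

Compound 3 `C#CCNC1CCc2c(SCCc3cccc(C)c3)cccc21` has not yet been measured. It differs from compound 1 in a single spot: methyl in place of bromo on an aromatic carbon. Within the data shown here, compound 2 differs from compound 1 in several places at once, so it offers no guide to this one change, and no measured pair shows it either.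

The step from compound 1 to compound 3 is expected to be small, a 1.8-fold higher number from compound 1 to compound 3 (0.25 log units; within the scatter), toward weaker inhibition and near the edge of the scatter. Compound 3 is thus estimated at 1100 nM, with a likely range from 400 nM to 3000 nM.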

Compound 3, half-maximal inhibitory concentration: 4960 nM
Beside the measured number, compound 3's estimate is 4.5-fold (0.65 log units) below it; measured number outside the range, above it.
By their numbers in this assay, from the lowest: compound 1; then compound 3; then compound 2.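

In this assay, this position does not treat bromo and methyl as interchangeable: going from 3-bromophenyl to 3-methylphenyl gives an 8.0-fold higher number from compound 1 to compound 3 (0.90 log units; beyond the scatter), so bromo gives the stronger inhibition of this pair. The earlier compounds shown here could not show this, as compound 1 and compound 2 differ in several places at once. The two groups have the same counts of heavy atoms, hydrogen-bond donors, hydrogen-bond acceptors and net charge, so those counts do not separate them, and no measurement here accounts for the gap.

On these data alone, how other groups at this aromatic carbon, such as chloro, methoxy or a nitrile, would compare with bromo remains open. As far as these compounds go, it is also open whether the same swap would give a similar step on a longer chain.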